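The compounds below may be only part of what the source reports. "The series", "measured", "known", "first", "only" and "open" are said of these compounds alone.

Three compounds share one core and differ only in the group carried on the amide-type nitrogen. Compound 1 `CCN(Cc1cccs1)C(=O)COc1ccc(C)cc1` bears an ethyl there and gives 8 nM in an assay on HEK293 cells for agonist activity at transient receptor potential cation channel subfamily M member 8 (Homo sapiens), read by fluorescence and calcium flux, with a stated time of 15 min; a higher number here means that more compound is needed for the effect, a lower number that less compound is needed. Compound 2 `Cc1ccc(OCC(=O)N(Cc2cccs2)C(C)(C)C)cc1` carries a tert-butyl and gives 11000 nM. Compound 3 `Cc1ccc(OCC(=O)N(Cc2cccs2)c2cnccn2)cc1` carries a pyrazin-2-yl and gives 1240 nM, the second highest of the three numbers, its nearest neighbour being compound 2 and the furthest compound 1. The steps are a 1400-fold higher number from compound 1 to compound 2 (3.14 log units; beyond the scatter), a 160-fold higher number from compound 1 to compound 3 (2.19 log units; beyond the scatter) and an 8.9-fold lower number from compound 2 to compound 3 (0.95 log units; beyond the scatter).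

Compound 4 `Cc1ccc(OCC(=O)N(Cc2cccs2)C2CC2)cc1` is not yet measured. It differs from compound 3 in that (cyclopropyl in place of pyrazin-2-yl on an amide-type nitrogen). For the measured compounds named here, no measured step swaps this pair of groups directly; the steps that bear on it are the ones from compound 1, whose ethyl is the smallest group in the set and gives the lowest number, a 160-fold higher number from compound 1 to compound 3 (2.19 log units; beyond the scatter) and a 1400-fold higher number from compound 1 to compound 2 (3.14 log units; beyond the scatter). Cyclopropyl, a three-membered ring of carbon only, is nearer in count to ethyl than to either pyrazin-2-yl or tert-butyl. Compound 4 is therefore expected to come out close to compound 1, giving an estimated 30 nM with a range from 5 nM to 300 nM, which would mean an expected 41-fold lower number from compound 3 to compound 4 (1.62 log units; beyond the scatter).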

Compound 4, half-maximal effective concentration: 8 nM
Beside the measured number, compound 4's estimate is 3.8-fold (0.57 log units) above it, and the stated range covers the measured number.
By their numbers in this assay, from the lowest: compounds 1 and 4 (each within the scatter of the next); then compound 3; then compound 2.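

The position on the amide-type nitrogen turns out not to penalise every ring: in this assay, cyclopropyl in place of pyrazin-2-yl gives a 160-fold lower number from compound 3 to compound 4 (2.19 log units; beyond the scatter), so a ring at this place can go with a low number, and what the pyrazin-2-yl result reflects is not a ring as such. Nor does carrying only carbon settle the outcome, since cyclopropyl in place of tert-butyl, both groups without hetero atoms, gives a 1400-fold lower number from compound 2 to compound 4 (3.14 log units; beyond the scatter), the widest gap seen here together with the one between the ethyl and tert-butyl compounds. Cyclopropyl in place of ethyl gives no change at the digits printed from compound 1 to compound 4 (within the scatter), so this position accepts a small open chain and a three-membered carbon ring alike, and the four compounds fall into a low pair, compound 1 and compound 4, and two compounds with much higher numbers.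

The compounds shown carry no measurement that would explain why these groups differ so sharply. As far as these compounds go, it remains open whether isopropyl, cyclobutyl or a longer chain such as n-butyl on this nitrogen would stay with that low pair or move toward compound 2, and whether a phenyl ring would behave like pyrazin-2-yl.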